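Triazine series: dimethylpiperidine replacing phenylpiperazine on the core

The source may hold more compounds than are shown below. What is called first, only, known or untested is meant among the compounds shown, and "the series" means these compounds.

In a functional assay on DU-145 cells (Homo sapiens) for cytotoxicity, read by sulforhodamine B assay, with a stated time of 48 h (on this read-out lower numbers stand for stronger inhibition of growth and higher numbers for weaker inhibition of growth), compound 1 `N#Cc1ccc(Nc2nc(Oc3ccnc4ccccc34)nc(N3CCN(c4ccccc4)CC3)n2)cc1C(F)(F)F` gives only a limit, > 100000 nM. Compound 2 `N#Cc1ccc(Nc2nc(Oc3ccnc4ccccc34)nc(N3CCN(c4cccc(Cl)c4Cl)CC3)n2)cc1C(F)(F)F` likewise gives only a limit, > 100000 nM. Among the compounds with values here, the step that the two limits leave unreadable from compound 1 to compound 2 cannot be sized, the sole point of evidence being (the limit of > 100000 nM in this assay, at which 2 of the 2 values shown sit). Compound 3 `CC1CC(C)CN(c2nc(Nc3ccc(C#N)c(C(F)(F)F)c3)nc(Oc3ccnc4ccccc34)n2)C1` alters the core of compound 1 by 3,5-dimethylpiperidin-1-yl in place of 4-phenylpiperazin-1-yl on an aromatic carbon. Within the data shown here, no measured step bears on this change, and compound 1 stands at the limit, so no readable step is expected in this assay. Compound 3 is expected to give 150000 nM, within 30000 nM to 600000 nM, which would be a step that the limit leaves unreadable from compound 1 to compound 3.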

Compound 3, concentration for 50% growth inhibition: 27200 nM
Compound 3: the middle estimate sits 5.5-fold (0.74 log units) above what was measured; measured number below the stated range.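

In this assay, this position on the shared core can carry a group that gives a readable value: 3,5-dimethylpiperidin-1-yl in place of 4-phenylpiperazin-1-yl is an at least 3.6-fold lower number from compound 1 to compound 3 (0.56 log units; beyond the scatter). Compound 3 is the only compound shown with a number rather than a limit. The size of the step remains a bound, as compound 1 gives only a limit: the limit of > 100000 nM in this assay, at which 2 of the 3 values shown sit.

Open, on these data alone, is whether the change in compound 3 traces to the loss of the phenyl ring, the piperidine ring or its two methyl groups. Unsubstituted piperidin-1-yl or morpholin-4-yl at this position would help separate these.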